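Swapping a Propyl Chain for a Pyridine Ring

The source may hold more compounds than are shown below. What is called first, only, known or untested is meant among the compounds shown, and "the series" means these compounds.

Of the compounds shown here, three sharing a sugar-linked core have been measured in an assay on isolated protein for binding affinity to Equilibrative nucleoside transporter 1 (Homo sapiens); a higher number here means a weaker inhibitor, a lower number a stronger inhibitor. Compound 1 `O=[N+]([O-])c1ccc2c(c1)CCN(c1ncnc3c1ncn3[C@@H]1O[C@H](CO)[C@@H](O)[C@H]1O)C2` gives 182 nM, compound 2 `OC[C@H]1O[C@@H](n2cnc3c(SC4CCCCC4)ncnc32)[C@H](O)[C@@H]1O` gives 6310 nM, and compound 3 `CCCCSc1nc(N)nc2c1ncn2[C@@H]1O[C@H](CO)[C@@H](O)[C@H]1O` gives 12000 nM. Compound 3 thus carries the highest number of the three: its gap to compound 2 sits within the scatter, while the gap to compound 1 lies beyond it. Compound 4 `Nc1nc(SCc2ccccn2)c2ncn([C@@H]3O[C@H](CO)[C@@H](O)[C@H]3O)c2n1` has not yet been measured in this assay. It differs from compound 3 in one spot: pyridin-2-yl in place of propyl on a saturated chain carbon bound to a sulfur. For the measured compounds named here, no measured pair shows this exact change, so the expectation rests on the neighbours alone. The step from compound 3 to compound 4 is expected to be a modest move toward stronger inhibition, near the edge of the scatter, a 2.7-fold lower number from compound 3 to compound 4 (0.43 log units; beyond the scatter). Compound 4 is therefore estimated at 4500 nM, within a range from 1000 nM to 20000 nM.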

Compound 4, half-maximal inhibitory concentration: 34700 nM
For compound 4 the middle estimate is 7.7-fold (0.89 log units) below the measured one; measured number outside the range, above it.
By their numbers in this assay, from the lowest: compound 1; then compounds 2 and 3 (each within the scatter of the next); then compound 4.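

In this assay, putting pyridin-2-yl in place of propyl on a saturated chain carbon bound to a sulfur gives weaker inhibition, with a 2.9-fold higher number from compound 3 to compound 4 (0.46 log units; beyond the scatter) as the step. For the compounds shown here, this is the first direct reading of a change at this position, and it shows that a six-membered aromatic ring there gives no gain over the propyl end of the chain. Nothing measured here explains the shift. As far as these compounds go, whether a phenyl ring, which has no ring nitrogen, would behave like pyridin-2-yl remains open. So does the effect of an amine or a carboxylic acid at this spot.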